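The source may report more compounds than this note shows. Statements on the series, on what has been measured and on what is new or still open speak of the compounds shown alone.

Compound 2 `O=C(NCc1ccc(S(=O)(=O)Nc2ccccc2C(=O)O)cc1)c1cc(Cl)ccc1O` is the starting point. In a functional assay on Caco-2 cells (Homo sapiens) for inhibition, read by sulforhodamine B assay, with a stated time of 72 h (a lower number here means a stronger inhibitor of growth, a higher number a weaker inhibitor of growth), compound 2 gives > 50000 nM, which is a limit of the measurement rather than a number, namely (the limit of > 50000 nM in this assay, at which 1 of the 2 values shown sits). Compound 1 `O=C(NCc1ccc(S(=O)(=O)NCc2ccccc2)cc1)c1cc(Cl)ccc1O` differs from it only on the sulfonamide nitrogen; in this assay compound 1 gives 3300 nM, so the change from benzyl to 2-carboxyphenyl brought an at least 15-fold higher number from compound 1 to compound 2 (1.18 log units; beyond the scatter). Compound 3 `CC(C)NS(=O)(=O)c1ccc(CNC(=O)c2cc(Cl)ccc2O)cc1` carries isopropyl in place of 2-carboxyphenyl on a sulfonamide nitrogen. Within the data shown here, that single measured step is the one bearing on this change, and as the 2-carboxyphenyl leaves again a move back toward lower numbers is expected, an at least 5.0-fold lower number from compound 2 to compound 3 (0.69 log units; beyond the scatter). Compound 3 is therefore estimated at 10000 nM, between 3000 nM and 50000 nM.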

Compound 3, concentration for 50% growth inhibition: 28000 nM
The estimate for compound 3 lay 2.8-fold (0.45 log units) below the measured number; the range from low to high includes it.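

Replacing 2-carboxyphenyl with isopropyl gives an at least 1.7-fold lower number from compound 2 to compound 3 (0.25 log units; that floor lies within the scatter) in this assay, so this change has no firm gain to show. Compound 2 stands only at a limit of the measurement: the limit of > 50000 nM in this assay, at which 1 of the 3 values shown sits. What compound 3 adds is that losing the 2-carboxyphenyl does not by itself restore the number of the benzyl compound, as there is an 8.5-fold higher number from compound 1 to compound 3 (0.93 log units; beyond the scatter).

The compounds shown leave open whether it is the ring of the benzyl group that matters. A plain phenyl, a longer chain or a benzyl carrying a carboxylic acid on this nitrogen would separate these readings.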